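From compound 3 to compound 4: chloro for methyl

The source may report more compounds than this note shows. Statements on the series, on what has been measured and on what is new or still open speak of the compounds shown alone.

Measured in an ADME assay on HaCaT cells (Homo sapiens) for inhibition; on this read-out higher numbers stand for weaker inhibition and lower numbers for stronger inhibition:
- Compound 1 `COc1cc(-c2cc(C(=O)O)c3ccccc3n2)ccc1OCC(=O)Nc1ccccc1`: > 300000 nM (a limit)
- Compound 2 `COc1cc(-c2cc(C(=O)O)c3ccccc3n2)ccc1OCC(=O)Nc1ccccc1C`: 230000 nM
- Compound 3 `COc1cc(-c2cc(C(=O)O)c3ccccc3n2)ccc1OCC(=O)Nc1ccc(C)cc1`: > 300000 nM (a limit)

Compound 3 gives only a limit and sits at the limit of > 300000 nM in this assay, at which 2 of the 3 values shown sit. Compound 4 `COc1cc(-c2cc(C(=O)O)c3ccccc3n2)ccc1OCC(=O)Nc1ccc(Cl)cc1` differs from it by chloro in place of methyl on an aromatic carbon, para to a large group. Among the measured compounds shown here, no measured step covers chloro, so only the methyl steps bear on this change. These are an at least 1.3-fold lower number from compound 1 to compound 2 (0.11 log units; that floor lies within the scatter), an at least 1.3-fold higher number from compound 2 to compound 3 (0.11 log units; that floor lies within the scatter) and a step that the two limits leave unreadable from compound 1 to compound 3. None of them shows a change beyond the scatter, so no clear step in either direction is expected in this assay. The expected step is an at least 1.0-fold lower number from compound 3 to compound 4 (0.02 log units; that floor lies within the scatter). For compound 4 the estimated value is 280000 nM, with an expected range of 130000 nM to 500000 nM.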

Compound 4, half-maximal inhibitory concentration: > 300000 nM
Compound 4: no number, only a limit; the forecaster's own chance of this, stated with the estimate: 60%; middle value at least 1.0-fold (0.02 log units) from the limit.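

In this assay compound 4 gives > 300000 nM, which is a limit. Among the compounds shown here, the steps to compound 4 from compound 1 and compound 3 cannot be read, and the one readable step is an at least 1.3-fold higher number from compound 2 to compound 4 (0.11 log units; that floor lies within the scatter), so chloro on this aromatic carbon, para to a large group, shows no change beyond the scatter. Compound 4 joins the other compounds at the limit: the limit of > 300000 nM in this assay, at which 3 of the 4 values shown sit.

Going by these compounds, how compound 1, compound 3 and compound 4 order among themselves stays open. Also open, on these data alone, is whether an amine or a nitrile in place of chloro would give a readable value.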